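Chloro Added to an Unmeasured Analogue

The compounds below may be only part of what the source reports. "The series", "measured", "known", "first", "only" and "open" are said of these compounds alone.

Four compounds share one core. Compound 1 `COc1cc(/C=C2\C(=O)Nc3ccccc32)ccc1OCCCN1CCN(c2ccccn2)CC1` carries no number in an ADME assay on MCF-10A cells (Homo sapiens) for cytotoxicity, read by MTT assay, with a stated time of 48 h; a lower number here means a stronger inhibitor, a higher number a weaker inhibitor: for compound 1 the entry reads "not determined" (no result reported), no result having been reported. Compound 3 `COc1cc(/C=C2\C(=O)Nc3ccccc32)ccc1OCCCN1CCN(c2ncccc2C(F)(F)F)CC1` likewise has none, and in this assay compound 3 is recorded as "not determined" (no result reported). Among the compounds with values here, compound 2 `COc1cc(/C=C2\C(=O)Nc3ccc(Cl)cc32)ccc1OCCCN1CCN(c2ccccn2)CC1` is the only one with a value, and in this assay compound 2 gives 51300 nM, a weak effect on these cells. Compound 3 thus stands nowhere on the scale, and there is no figure from which a step could start. Compound 4 `COc1cc(/C=C2\C(=O)Nc3ccc(Cl)cc32)ccc1OCCCN1CCN(c2ncccc2C(F)(F)F)CC1` differs from compound 3 in one place: chloro in place of hydrogen on an aromatic carbon. Within the data shown here, the same swap separates compound 1 from compound 2, yet compound 1 also lacks a number, so no measured step of this kind exists and neither the size nor the direction of the change in this assay can be read from these data. Among the measured compounds shown here, without a step to lean on, the one reported value is the only guide, and compound 2 marks that point with 51300 nM. Compound 4 is expected to land in the same weak region, estimated at 40000 nM with a range from 15000 nM to 100000 nM.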

Compound 4, half-maximal inhibitory concentration: 41300 nM
Compound 4: the middle estimate sits 1.0-fold (0.01 log units) below what was measured, within the range that was stated.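

In this assay, within the data shown here, the new result supplies the first step that can be read: a 1.2-fold lower number from compound 2 to compound 4 (0.09 log units; within the scatter) when trifluoromethyl takes the place of hydrogen on an aromatic carbon. That step lies within the usual scatter, so in the presence of chloro, this swap shows no measurable difference in the effect on these cells. Nothing available here explains this outcome.

The chloro steps still cannot be read, as neither compound 1 nor compound 3 has a number to start from, which leaves the effect of chloro on this core unknown. On these data alone, it also remains open whether an amine or a carboxylic acid on the aromatic carbon that carries trifluoromethyl would shift the number beyond the scatter.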